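The source may report more compounds than this note shows. Statements on the series, on what has been measured and on what is new or still open speak of the compounds shown alone.

Measured compounds:
Compound 1 `CCOC(=O)C1(Cc2ccccc2)CN(c2ccccc2)Cc2nnn(Cc3cccc(Cl)c3)c21` — in an ADME assay on HEL cells (Homo sapiens) for cytotoxicity, read by microscopy, with a stated time of 3 days (a lower number here means that less compound is tolerated, a higher number that more compound is tolerated), compound 1 gives > 100000 nM, a limit of the assay rather than a number.
Compound 2 `CCOC(=O)C1(Cc2ccccc2)CN(c2ccccc2)Cc2nnn(Cc3ccccc3Cl)c21` — in this assay compound 2 gives > 100000 nM, likewise a limit of the assay.

Compound 2 therefore stands only at a limit in this assay, and the step that the two limits leave unreadable from compound 1 to compound 2 cannot be read, as both of its ends are limits. Not yet measured is compound 3 `CCOC(=O)C1(Cc2ccccc2)CN(c2ccccc2)Cc2nnn(Cc3ccc(Cl)c(Cl)c3)c21`. The change from compound 2 is 3,4-dichlorophenyl in place of 2-chlorophenyl on a saturated chain carbon bound to an aromatic nitrogen. Within the data shown here, the single measured step is the only one bearing on this change; it concerns another chlorophenyl exchange at the same place, and its size is not readable. What the series does show is the limit of > 100000 nM in this assay, at which 2 of the 2 values shown sit. No step beyond the scatter is expected in this assay. The expected step for compound 3 is a number no higher from compound 2 to compound 3 (the limit leaves the size open), flat at the limit. Compound 3 is estimated at 100000 nM, expected between 30000 nM and 300000 nM, and most likely reported again only as a limit.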

Compound 3, minimum cytotoxic concentration: > 100000 nM
Compound 3: a limit, no number; the forecaster's own chance of this, stated with the estimate: 80%; the middle value sits exactly at the limit.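

In this assay, among these compounds, compound 3 gives > 100000 nM, again a limit and not a number, so no step among compound 1, compound 2 and compound 3 can be read. The compounds shown leave open at what concentration any of them turns cytotoxic, and whether the chlorine pattern alters that concentration: the limit of > 100000 nM in this assay, at which 3 of the 3 values shown sit.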